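A few compounds are considered here, and "the series" means these few. Any claim that something is new, unique, unknown or untested is made for them only; others in the source may bear on it.

Compound 1 `CCN(CC)c1ccc2cc(C(=O)c3ccc(N4CCN(C(=O)CN5CCNCC5)CC4)cc3)oc2c1` is the parent of this small set, and in a functional assay on SGC-7901 cells (Homo sapiens) for cytotoxicity, read by MTT assay, with a stated time of 48 h (a lower number here means a stronger inhibitor, a higher number a weaker inhibitor), compound 1 gives 1220 nM. Compound 3 `CCN(CC)c1ccc2cc(C(=O)c3ccc(N4CCN(C(=O)CN5CCN(S(=O)(=O)c6ccc(C#N)cc6)CC5)CC4)cc3)oc2c1` carries a (4-cyanophenyl)sulfonyl group on the ring amine that is free in compound 1; in this assay compound 3 reaches only the limit of > 40000 nM, a boundary of the measurement rather than a number. Compound 2 `CCN(CC)c1ccc2cc(C(=O)c3ccc(N4CCN(C(=O)CN5CCN(S(=O)(=O)c6ccc(C(F)(F)F)cc6)CC5)CC4)cc3)oc2c1` likewise sits at the limit of > 40000 nM in this assay. The step of an at least 32-fold higher number from compound 1 to compound 3 (1.51 log units; beyond the scatter) is therefore the one clear signal here, while the step that the two limits leave unreadable from compound 2 to compound 3 cannot be read, since both ends rest on (the limit of > 40000 nM in this assay, at which 2 of the 3 values shown sit).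

Compound 4 `CCN(CC)c1ccc2cc(C(=O)c3ccc(N4CCN(C(=O)CN5CCN(Cc6ccc(C(F)(F)F)cc6)CC5)CC4)cc3)oc2c1` differs from compound 3 by 4-(trifluoromethyl)benzyl in place of (4-cyanophenyl)sulfonyl on an amine nitrogen in a ring. Among the compounds with values here, no measured step covers this exact change. Within the data shown here, the only guidance is that compound 1, with the bare ring amine, gives a readable number, whereas compound 3 does not. Compound 4 is expected to fall between those two situations, at an estimated 6000 nM with a range from 1200 nM to 40000 nM, which would mean an expected step of an at least 6.6-fold lower number from compound 3 to compound 4 (0.82 log units; beyond the scatter).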

Compound 4, half-maximal inhibitory concentration: 32000 nM
The estimate for compound 4 lay 5.3-fold (0.73 log units) below the measured number, and the stated range covers the measured number.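

On the ring nitrogen that is free in compound 1, a benzyl group with no sulfonyl link also gives a large loss in this assay: putting 4-(trifluoromethyl)benzyl there gives a 26-fold higher number from compound 1 to compound 4 (1.42 log units; beyond the scatter), so within these compounds the loss does not depend on the sulfonyl group. Compound 4 also gives a real number here, not a limit of the assay. Against the sulfonyl partner the change shows only an at least 1.2-fold lower number from compound 3 to compound 4 (0.09 log units; that floor lies within the scatter), and no gain can be claimed from it, because one end of that step is a limit: the limit of > 40000 nM in this assay, at which 2 of the 4 values shown sit.

Still open, as far as these compounds go, is how far a simple methyl or acetyl group on that nitrogen would stay close to compound 1. Also open, from the compounds shown here alone, is what an amine or a carboxylic acid on the benzyl ring would do.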